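Amide in place of basic piperidine at the ring carbon

The source may report more compounds than this note shows. Statements on the series, on what has been measured and on what is new or still open speak of the compounds shown alone.

Compound 1 `Cc1cc(C)c(S(=O)(=O)N2CCC(N3CCCCCC3)CC2)c(C)c1` gives 5.3 nM in a functional assay on DLD-1 cells (Homo sapiens) for antiproliferative activity, read by CellTiter-Glo, with a stated time of 72 h; on this read-out higher numbers stand for weaker inhibition and lower numbers for stronger inhibition. Compound 2 `Cc1cc(C)c(S(=O)(=O)N2CCC(N3CCC(C(C)C)CC3)CC2)c(C)c1` gives 0.3 nM in this assay, the lowest of the two numbers; the step of an 18-fold lower number from compound 1 to compound 2 (1.25 log units; beyond the scatter) shows how strongly this position moves the read-out. Compound 3 `CCCC(=O)NC1CCN(S(=O)(=O)c2c(C)cc(C)cc2C)CC1` differs from compound 2 by (propylcarbonyl)amino in place of 4-isopropylpiperidin-1-yl on a saturated ring carbon. For the measured compounds named here, no measured step exchanges a ring amine for an acyclic amide, so the one step from compound 1 to compound 2 serves only as a gauge of sensitivity at this position. A large step toward weaker inhibition is expected, a 1000-fold higher number from compound 2 to compound 3 (3.00 log units; beyond the scatter). Compound 3 is estimated at 300 nM, with a range from 20 nM to 5000 nM.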

Compound 3, half-maximal inhibitory concentration: > 5000 nM
Compound 3 was reported as a limit; the forecaster's own chance of this, stated with the estimate: 20%; middle value at least 16-fold (1.22 log units) away from the limit.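

Compound 3 stands only as a limit: the limit of > 5000 nM in this assay, at which 1 of the 3 values shown sits. Exchanging one ring amine for another at this ring carbon had moved the number by an 18-fold lower number from compound 1 to compound 2 (1.25 log units; beyond the scatter), whereas (propylcarbonyl)amino in place of either ring amine gives an at least 16000-fold higher number from compound 2 to compound 3 (4.22 log units; beyond the scatter) and an at least 940-fold higher number from compound 1 to compound 3 (2.97 log units; beyond the scatter). Both steps to the amide therefore reach well past the step between the two ring amines, though their true size remains bounded only by the limit.

Still open, on these data alone, is whether the carbonyl or the absence of a ring accounts for this loss. A butylamino group at the same ring carbon would separate the two.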